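Swapping a methoxy for chloro on the amide chain

This account rests on a few compounds, and the source may have more. Where it says the series, first, only, none or still open, it means among the compounds named here.

Among the compounds with values here, compound 1, `COCC(=O)N(Cc1ccc(OC)c(O)c1)c1cc(OC)c(OC)c(OC)c1`, is the stronger of the two compounds measured so far in a functional assay on KYSE-450 cells (Homo sapiens) for inhibition, read by MTT assay, with a stated time of 48 h; a higher number here means a weaker inhibitor, a lower number a stronger inhibitor: compound 1 gives 460 nM. Compound 2, `COc1ccc(N(Cc2cc(OC)c(OC)c(OC)c2)C(=O)CCl)cc1O`, gives 29800 nM, a far higher number, well beyond the usual scatter, so compound 1 clearly stands ahead.

Compound 3, `COc1ccc(CN(C(=O)CCl)c2cc(OC)c(OC)c(OC)c2)cc1O`, has not yet been measured. It differs from compound 1 by a single change: chloro in place of methoxy on a saturated chain carbon bound to a carbonyl carbon. The same difference, cut one bond further out, reads methoxymethyl to chloromethyl.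

Within the data shown here, no measured pair shows this exact step, so its size cannot be read off directly. Compound 2 also carries a (chloromethyl)carbonyl and gives 29800 nM, but its other groups differ too, so the step is uncertain. The step from compound 1 to compound 3 is expected to be a moderate weakening, a 3.3-fold higher number from compound 1 to compound 3 (0.51 log units; beyond the scatter). Compound 3 is therefore estimated at 1500 nM, with a range from 300 nM to 8000 nM.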

Compound 3, half-maximal inhibitory concentration: 210 nM
For compound 3 the middle estimate is 7.1-fold (0.85 log units) above the measured one; the whole stated range lies above it.
By their numbers in this assay, from the lowest: compound 3; then compound 1; then compound 2.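

In this assay, within the data shown here, this is the first direct reading of the saturated chain carbon bound to a carbonyl carbon, with nothing else changed: chloro in place of methoxy gives a 2.2-fold lower number from compound 1 to compound 3 (0.34 log units; beyond the scatter), a modest gain that lies beyond the scatter. The methoxy is therefore not needed here for this activity, and a chloromethyl on the carbonyl does better than a methoxymethyl on the same core. Nothing measured on these compounds accounts for the gain.

As far as these compounds go, this single swap gives only two points at this position, so it remains open how a fluoro, an amine or a longer chain would behave in the same place. From the compounds shown here alone, it also remains open whether the same change would give a step of similar size on a different core.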